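A few compounds are considered here, and "the series" means these few. Any claim that something is new, unique, unknown or untested is made for them only; others in the source may bear on it.

Among the measured compounds shown here, in an assay on HEK293 cells for negative allosteric modulation of metabotropic glutamate receptor 5 (Homo sapiens), read by FLIPR (on this read-out lower numbers stand for stronger inhibition and higher numbers for weaker inhibition), compound 2 `O=C(c1cccc(F)c1)N1CC(c2nc(-c3cccc(Cl)c3)no2)C1` gives 780 nM, the only number in hand. Compound 1 `O=C(N1CCCCC1)N1CC(c2nc(-c3cccc(Cl)c3)no2)C1` sits at the limit of this assay, > 10000 nM. For the measured compounds named here, the single measured step, an at least 12-fold lower number from compound 1 to compound 2 (1.10 log units; beyond the scatter), concerns a different change, the aryl group replacing piperidin-1-yl. Compound 3 `O=C(c1ccccc1F)N1CC(c2nc(-c3cccc(Cl)c3)no2)C1` differs from compound 2 by 2-fluorophenyl in place of 3-fluorophenyl on a carbonyl carbon. Going by the values given here, no measured step bears on moving the fluorine, so a step within the scatter is expected, a 1.3-fold higher number from compound 2 to compound 3 (0.11 log units; within the scatter). Compound 3 is therefore estimated at 1000 nM in this assay, with a range from 300 nM to 4000 nM.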

Compound 3, half-maximal inhibitory concentration: 670 nM
Beside the measured number, compound 3's estimate is 1.5-fold (0.17 log units) above it; the measured number falls inside the stated range.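

With this assay, 2-fluorophenyl and 3-fluorophenyl on the carbonyl carbon read alike, a 1.2-fold lower number from compound 2 to compound 3 (0.07 log units; within the scatter), so the two fluorine placements shown cannot be told apart. The drop from the piperidin-1-yl compound now holds for a second fluorinated aryl group, an at least 14-fold lower number from compound 1 to compound 3 (1.17 log units; beyond the scatter). The size of that step remains open-ended, as compound 1 gives only a limit: the limit of > 10000 nM in this assay, at which 1 of the 3 values shown sits.

The compounds shown leave open whether phenyl without fluorine, pyridyl or cyclohexyl on the same carbonyl carbon would read like these two aryl groups.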